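The compounds below may be only part of what the source reports. "The series", "measured", "known", "first", "only" and "open" are said of these compounds alone.

Going by the values given here, in a functional assay on A549 cells (Homo sapiens) for cytotoxicity, read by MTT assay (on this read-out lower numbers stand for stronger inhibition and higher numbers for weaker inhibition), compound 1 `CC(C)C[C@@H](NC(=S)Nc1ccccc1)c1nc2ccccc2[nH]1` gives 18700 nM, the lowest of the two numbers so far, and compound 2 `CC(C)C[C@@H](NC(=S)NCc1ccccc1)c1nc2ccccc2[nH]1` gives 22400 nM, so the only measured step, a 1.2-fold higher number from compound 1 to compound 2 (0.08 log units; within the scatter), sits within the scatter. Compound 3 `C[C@@H](NC(=S)Nc1ccccc1)c1nc2ccccc2[nH]1` differs from compound 1 by hydrogen in place of isopropyl on a saturated chain carbon, two bonds along the chain from an amide-type nitrogen and an aromatic carbon. Among the compounds with values here, no measured step touches that saturated chain carbon: the benzyl-for-phenyl change on the amide-type nitrogen tells nothing about trimming isobutyl to methyl, so the working expectation is a modest rise in the number, or none beyond the scatter. Compound 3 is estimated at 32000 nM, range 13000 nM to 80000 nM, a step of a 1.7-fold higher number from compound 1 to compound 3 (0.23 log units; within the scatter).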

Compound 3, half-maximal inhibitory concentration: 14800 nM
The estimate for compound 3 lay 2.2-fold (0.33 log units) above the measured number; measured number inside the range.
By their numbers in this assay, from the lowest: compounds 3, 1 and 2 (each within the scatter of the next).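

Hydrogen in place of isopropyl on a saturated chain carbon, two bonds along the chain from an amide-type nitrogen and an aromatic carbon, gives a 1.3-fold lower number from compound 1 to compound 3 (0.10 log units; within the scatter) and is the first read on this position. Cutting isobutyl to methyl removes 3 heavy atoms without a step beyond the scatter, so the larger chain is not required to keep the number at this level. No supporting measurement bears on this result.

From the compounds shown here alone, whether a longer chain, an amine or a carboxylic acid on this carbon would move the number beyond the scatter remains open.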